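From dimethylamino to pyrrolidin-1-yl on a side chain

A few compounds are considered here, and "the series" means these few. Any claim that something is new, unique, unknown or untested is made for them only; others in the source may bear on it.

Three related compounds have been measured so far. In a functional assay on MCF7 cells (Homo sapiens) for antiproliferative activity, read by MTT assay, with a stated time of 48 h (on this read-out lower numbers stand for stronger inhibition and higher numbers for weaker inhibition), compound 1 (`CCN(CC)Cc1cc2cc(c1O)Oc1ccc(cc1)CCc1ccc(CN(CC)CC)c(O)c1-c1ccc(cc1O)CC2`) gives 1050 nM as a plain number. Compound 2 (`CC(C)(C)OC(=O)N1CCN(Cc2cc3cc(c2O)Oc2ccc(cc2)CCc2ccc(CN4CCN(C(=O)OC(C)(C)C)CC4)c(O)c2-c2ccc(cc2O)CC3)CC1`) gives > 20000 nM in this assay and this is a limit of the assay, not a number. Compound 3 (`CN(C)CCCOc1cccc2c1-c1ccc(cc1O)CCc1ccc(O)c(c1)Oc1ccc(cc1)CC2`) gives 3250 nM in this assay and so holds the higher of the two plain numbers, which means weaker inhibition than compound 1 by a gap beyond the usual scatter of repeat measurements.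

Compound 4 (`Oc1ccc2cc1Oc1ccc(cc1)CCc1cccc(OCCCN3CCCC3)c1-c1ccc(cc1O)CC2`) has not been measured yet. Set against compound 3, it carries pyrrolidin-1-yl in place of dimethylamino on a saturated chain carbon, three bonds along the chain from an oxygen on an aromatic ring. In other words, 3-(dimethylamino)propyl becomes 3-(pyrrolidin-1-yl)propyl. For the measured compounds named here, no measured pair shows this swap, so the expectation leans on compound 3 and its 3250 nM as the starting point. The step expected is a 1.1-fold lower number from compound 3 to compound 4 (0.03 log units; within the scatter) in this assay and this lies within the scatter, so no real shift in either direction is foreseen. In this assay the estimate for compound 4 is 3000 nM with an expected range from 1200 nM up to 8000 nM as a working guess.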

Compound 4, half-maximal inhibitory concentration: 3680 nM
The estimate for compound 4 lay 1.2-fold (0.09 log units) below the measured number; the range from low to high includes it.
By their numbers in this assay, from the lowest: compound 1; then compounds 3 and 4 (each within the scatter of the next). At a limit, above all of these: compound 2.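

In this assay, putting pyrrolidin-1-yl in place of dimethylamino on a saturated chain carbon, three bonds along the chain from an oxygen on an aromatic ring, gives a 1.1-fold higher number from compound 3 to compound 4 (0.05 log units; within the scatter), so this read-out does not separate the two compounds. This is the first pair shown that differs in one place, and it offers a direct look at this position: the group can grow from 3 heavy atoms to 5 and gain a five-membered non-aromatic ring with no shift that stands out from the scatter. Nothing among the measurements shown accounts for this absence of a shift.

For the compounds shown here, this pair tests only two closely related groups, so it remains open whether a piperidin-1-yl or morpholin-4-yl group, or a carboxylic acid in place of the amine, would give a similar number at this position. Going by these compounds, the role of chain length also remains open, since a 2-(pyrrolidin-1-yl)ethyl or a longer 4-(pyrrolidin-1-yl)butyl chain would be needed to show whether the distance from the oxygen matters.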